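Benzyloxy on compound 3: expected step

The source may report more compounds than this note shows. Statements on the series, on what has been measured and on what is new or still open speak of the compounds shown alone.

Of the compounds shown here, three have been read so far in a functional assay on MCF7 cells (Homo sapiens) for cytotoxicity, read by MTT assay, with a stated time of 72 h; on this read-out higher numbers stand for weaker inhibition and lower numbers for stronger inhibition. Among the compounds with values here, compound 3 (`CCOC(=O)c1c(C)oc2ncnc(Nc3ccccc3)c12`) gives 851000 nM, the only true number in the set. Compound 1 (`C#Cc1cccc(Nc2ncnc3oc(C)c(C(=O)OCC)c23)c1`) reads > 1000000 nM, which is a limit of the assay. Compound 2 (`CCOC(=O)c1c(C)oc2ncnc(Nc3cccc(Br)c3)c12`) reads > 1000000 nM, also a limit. The boundary that matters here is the limit of > 1000000 nM in this assay, at which 2 of the 3 values shown sit.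

Compound 4 (`CCOC(=O)c1c(C)oc2ncnc(Nc3ccc(OCc4ccccc4)cc3)c12`) carries benzyloxy in place of hydrogen on an aromatic carbon, para to a large group: benzyloxy in place of hydrogen on an aromatic carbon.

Within the data shown here, two measured steps bear on this change: an at least 1.1-fold lower number from compound 1 to compound 3 (0.07 log units; that floor lies within the scatter) and an at least 1.1-fold lower number from compound 2 to compound 3 (0.07 log units; that floor lies within the scatter). Both are floors, not sizes. The step that the two limits leave unreadable from compound 1 to compound 2 adds nothing. Neither the ethynyl nor the bromo compound reads lower than compound 3, so no step beyond the scatter is expected in this assay, and a reading at the limit remains quite possible.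

The expected change is a 1.1-fold higher number from compound 3 to compound 4 (0.02 log units; within the scatter).

The estimate for compound 4 is 900000 nM, with an expected range of 350000 nM to 2000000 nM.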

Compound 4, half-maximal inhibitory concentration: > 1000000 nM
Compound 4 ended at the assay's limit; the forecaster's own chance of this, stated with the estimate: 55%; middle value at least 1.1-fold (0.04 log units) from the limit.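

In this assay, benzyloxy in place of hydrogen on an aromatic carbon, para to a large group, gives an at least 1.1-fold higher number from compound 3 to compound 4 (0.07 log units; that floor lies within the scatter). Compound 4 reads > 1000000 nM, which is a limit of the assay and not a number. Benzyloxy, with 8 heavy atoms and one six-membered aromatic ring of carbon only, is a much larger entering group than ethynyl or bromo, and it too gives no true number, so all the substituted compounds shown now stand at the limit: the limit of > 1000000 nM in this assay, at which 3 of the 4 values shown sit.

On these data alone, the real size of the step from hydrogen to benzyloxy stays unknown, and so does whether this place can hold any group that brings a true number lower than that of compound 3, which gives 851000 nM. An amine or a carboxylic acid at this place, or a small ether such as methoxy, would test that.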